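Series notes: bromo to ethyl on the thioether aryl ring

The source may report more compounds than this note shows. Statements on the series, on what has been measured and on what is new or still open speak of the compounds shown alone.

Measured so far:
- Compound 1, `Cc1ccc(SCc2ccc(/C=C/C(=O)Nc3ccccc3N)cc2)cc1`: 22%
- Compound 2, `COc1ccc(SCc2ccc(/C=C/C(=O)Nc3ccccc3N)cc2)cc1OC`: 14.3%
- Compound 3, `Nc1ccccc1NC(=O)c1ccc(CSc2ccc(Br)cc2)cc1`: 10%

In a functional assay on SMMC-7721 cells (Homo sapiens) for inhibition, read by CCK-8 assay, with a stated time of 72 h, tested at 2 uM (a higher number here means more inhibition of growth at the concentration tested, a lower number less inhibition of growth), compound 3 gives the lowest of the three numbers. Its gap to compound 2 is within the scatter, its gap to compound 1 is beyond it. Going by the values given here, the one step among measured compounds, a number 7.7 percentage points lower from compound 1 to compound 2 (within the scatter), changes the aryl group on the sulfur in the cinnamamide pair and stays within the scatter.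

Compound 4, `CCc1ccc(SCc2ccc(C(=O)Nc3ccccc3N)cc2)cc1`, is not yet measured. It differs from compound 3 by ethyl in place of bromo on an aromatic carbon, on an aromatic carbon of a six-membered aromatic ring of carbon only, the same difference one bond further out reading 4-bromophenyl to 4-ethylphenyl. Among the compounds with values here, no measured pair exchanges bromo for ethyl, and the only step known, from compound 1 to compound 2, concerns a different pair of groups and lies within the scatter. No step beyond the scatter is therefore expected in this assay from compound 3 to compound 4, and the expected step is a number 3 percentage points higher from compound 3 to compound 4 (within the scatter). Compound 4 is estimated at 13%, with a range from 2% to 28%.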

Compound 4, percent growth inhibition at one concentration: 25.7%
Beside the measured number, compound 4's estimate is 12.7 percentage points below it, within the range that was stated.
By their numbers in this assay, from the lowest: compounds 3, 2, 1 and 4 (each within the scatter of the next, the first and the last beyond it).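

Ethyl in place of bromo on an aromatic carbon, para to a large group, gives the only step in the series that lies beyond the scatter: in this assay the change is a number 15.7 percentage points higher from compound 3 to compound 4 (beyond the scatter). This position on the thioether aryl ring therefore responds to the group it carries, which the earlier step in the cinnamamide pair, a number 7.7 percentage points lower from compound 1 to compound 2 (within the scatter), did not show. Going by these compounds alone, nothing measured so far bears on why the number moves, so the step stands as an observation only.

From the compounds shown here alone, whether the gain follows from ethyl itself or from the loss of bromo remains open, as does what a longer chain such as propyl, or an amine, would do at the same place. Going by these compounds, whether the exchange of bromo for ethyl carries over to the cinnamamide compounds is also open.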